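The source may hold more compounds than are shown below. What is called first, only, known or untested is meant among the compounds shown, and "the series" means these compounds.

Measured in a functional assay on MCF7 cells (Homo sapiens) for antiproliferative activity; a lower number here means a stronger inhibitor, a higher number a weaker inhibitor:
compound 1 `CC(C)=CCc1cc(C(=O)Nc2cc3ccc(OCC4CCCN(C)C4)c(C)c3oc2=O)ccc1O`: 2640 nM
compound 2 `CC(C)=CCc1cc(C(=O)Nc2cc3ccc(OCC4CCCNC4)c(C)c3oc2=O)ccc1O`: 790 nM
compound 3 `CC(C)=CCc1cc(C(=O)Nc2cc3ccc(OCCCNCCO)c(C)c3oc2=O)ccc1O`: 1560 nM

Compound 3, at 1560 nM, does not separate from either of the other two compounds: a 1.7-fold lower number from compound 1 to compound 3 (0.23 log units; within the scatter) and a 2.0-fold higher number from compound 2 to compound 3 (0.30 log units; within the scatter) both stay within the scatter. Only a 3.3-fold lower number from compound 1 to compound 2 (0.52 log units; beyond the scatter) goes beyond the scatter, and that modest step comes from a change on an amine nitrogen in a ring.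

Next is compound 4 `CC(C)=CCc1cc(C(=O)Nc2cc3ccc(OCCCNC4CCCCC4)c(C)c3oc2=O)ccc1O`, which differs from compound 3 by cyclohexyl in place of 2-hydroxyethyl on an amine nitrogen. Within the data shown here, no measured step makes this exact change. The nearest evidence is the replacement of the ring-bearing side chains of compound 1 and compound 2 by the open chain of compound 3, seen in a 1.7-fold lower number from compound 1 to compound 3 (0.23 log units; within the scatter) and a 2.0-fold higher number from compound 2 to compound 3 (0.30 log units; within the scatter). Neither step exceeds the scatter, so no step beyond the scatter is expected in this assay, and no direction is favoured. The expected change is a 1.2-fold lower number from compound 3 to compound 4 (0.08 log units; within the scatter). Compound 4 is estimated at 1300 nM. The expected range for compound 4 runs from 500 nM to 3400 nM.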

Compound 4, half-maximal inhibitory concentration: 1070 nM
Compound 4: middle estimate off by 1.2-fold (0.08 log units), on the high side; measured number inside the range.
By their numbers in this assay, from the lowest: compounds 2, 4, 3 and 1 (each within the scatter of the next, the first and the last beyond it).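

In this assay, cyclohexyl, which has no hydrogen-bond donor or acceptor, stands in place of 2-hydroxyethyl on the amine nitrogen with no step beyond the scatter (a 1.5-fold lower number from compound 3 to compound 4 (0.16 log units; within the scatter)). Set against the ring-bearing side chains, 2-(cyclohexylamino)ethyl stays within the scatter of piperidin-3-yl (a 1.4-fold higher number from compound 2 to compound 4 (0.13 log units; within the scatter)) but gives a modest step beyond the scatter from 1-methylpiperidin-3-yl (a 2.5-fold lower number from compound 1 to compound 4 (0.39 log units; beyond the scatter)), the first open-chain side chain here to separate from compound 1. No supporting measurement bears on the reason for these steps.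

Still open, on these data alone, is how a phenyl group or a carboxylic acid on this amine nitrogen would read in this assay. A longer chain ahead of the amine nitrogen, and a methyl on that nitrogen in the open-chain compounds, also remain untested in the compounds shown.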